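Oxygen for sulfur in the side ring on two cores

This account rests on a few compounds, and the source may have more. Where it says the series, first, only, none or still open, it means among the compounds named here.

Two cores carry the same sulfonyl-linked side chain. Compound 1 `Cc1ccc(C2CNN=C2S(=O)(=O)CC2=NCCS2)cc1` and compound 3 `Cc1ccc(C2CNN=C2S(=O)(=O)CC2=NCCO2)cc1` share one core; compound 2 `Cc1ccc(-c2c[nH]nc2S(=O)(=O)CC2=NCCS2)cc1` and compound 4 `Cc1ccc(-c2c[nH]nc2S(=O)(=O)CC2=NCCO2)cc1` share the other. How the two cores differ is not broken down here.

In a functional assay, read by Griess assay, with a stated time of 150 min, tested at 50 ug/mL (on this read-out higher numbers stand for a stronger effect at the one concentration tested and lower numbers for a weaker effect), compound 1 gives 43.1% and compound 3 gives 45.9%. The change between them is a group of 5 heavy atoms (3 carbon, 1 nitrogen, 1 oxygen; one five-membered non-aromatic ring with 2 hetero atoms) in place of a group of 5 heavy atoms (3 carbon, 1 nitrogen, 1 sulfur; one five-membered non-aromatic ring with 2 hetero atoms), on a saturated chain carbon bound to a sulfonyl sulfur, and the step of a number 2.8 percentage points higher from compound 1 to compound 3 (within the scatter) lies within the scatter, so nothing separates the two side rings on this core.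

Compound 2 is reported in this assay as "not active" (no number reported), with no number behind it. Compound 4 carries the same kind of change on this core, (a group of 5 heavy atoms (3 carbon, 1 nitrogen, 1 oxygen; one five-membered non-aromatic ring with 2 hetero atoms) in place of a group of 5 heavy atoms (3 carbon, 1 nitrogen, 1 sulfur; one five-membered non-aromatic ring with 2 hetero atoms), on a saturated chain carbon bound to a sulfonyl sulfur), with the place the same in both pairs. Among the measured compounds shown here, no step is known for it.

The expectation for compound 4 rests on compound 2 having given "not active" (no number reported) and on the change having made only a number 2.8 percentage points higher from compound 1 to compound 3 (within the scatter) on the other core, so the change itself offers no ground to expect a move out of the inactive range. Compound 4 is therefore estimated at 10% in this assay, with the range 0% to 25%, and a fair chance that the read-out again reports no number at all.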

Compound 4, a percentage reported as activity, at one concentration (the size of the read-out at that concentration, not a potency): 59.4%
For compound 4 the middle estimate is 49.4 percentage points below the measured one; measured number outside the range, above it.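

In this assay, among the compounds shown here, compound 2 carries no number, so no step from compound 2 to compound 4 can be read, even though compound 4 gives 59.4% as a plain number. The compounds shown leave open whether the oxygen-for-sulfur change in the side ring has a different size on the core of compound 4 than on the core of compound 1. No measurement shown here accounts for the result of compound 4.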